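A Methoxy Group Replaces Two Chlorines

The source may hold more compounds than are shown below. What is called first, only, known or untested is meant among the compounds shown, and "the series" means these compounds.

For the measured compounds named here, in a functional assay on MCF7 cells (Homo sapiens) for inhibition, read by MTT assay, with a stated time of 48 h (on this read-out higher numbers stand for weaker inhibition and lower numbers for stronger inhibition), compound 2 `O=C(CC(c1c(Cl)cccc1Cl)C(C(=O)Nc1ccccn1)C(=O)Nc1ccccn1)c1ccccc1` gives 16700 nM, the only number available so far. Its close relative, compound 1 `O=C(CC(c1cccs1)C(C(=O)Nc1ccccn1)C(=O)Nc1ccccn1)c1ccccc1`, has a different aromatic group on the same carbon and is reported as "not active" (no number reported), with no number attached. Going by the values given here, compound 2 is therefore a single reference point, and there is no measured step to show how far such a swap can move the result.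

The next compound, compound 3 `COc1ccc(C(CC(=O)c2ccccc2)C(C(=O)Nc2ccccn2)C(=O)Nc2ccccn2)cc1`, keeps the shared core and changes one group: 4-methoxyphenyl in place of 2,6-dichlorophenyl on a saturated chain carbon bound to two saturated chain carbons. The size of the group stays the same by heavy-atom count, but the chlorines are gone and a hydrogen-bond acceptor is gained.

The estimated step of a 1.8-fold higher number from compound 2 to compound 3 (0.25 log units; within the scatter) is small and leans towards weaker inhibition. That lean rests on compound 1, reported as "not active" (no number reported), which shows that this group can be exchanged with a loss of measurable activity in this assay. For compound 3 the expected value is 30000 nM, with an estimated range from 10000 nM to 90000 nM.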

Compound 3, half-maximal inhibitory concentration: 48300 nM
Compound 3: middle estimate off by 1.6-fold (0.21 log units), on the low side; the measured number falls inside the stated range.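

Swapping the group on a saturated chain carbon bound to two saturated chain carbons from 2,6-dichlorophenyl to 4-methoxyphenyl gives a 2.9-fold higher number from compound 2 to compound 3 (0.46 log units; beyond the scatter) in this assay and so moves the result towards weaker inhibition. For the compounds shown here, this is the first step at this place that can be read as a number, and it shows that the read-out responds to the group carried there, even though both values lie in a weak range. The two groups have the same heavy-atom count and the same six-membered aromatic ring of carbon only, so matching those features does not hold the number steady, and no measurement shown explains the step.

The compounds shown leave open whether the shift follows the loss of the chlorines or the arrival of the methoxy group, a question that a plain phenyl or a 4-chlorophenyl group at this place could help to separate. Compound 1 is reported as "not active" (no number reported) in this assay and so its steps to the other two compounds cannot be read.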